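The source may hold more compounds than are shown below. What is called first, only, known or untested is meant among the compounds shown, and "the series" means these compounds.

Measured compounds:
- compound 1, `CCCc1ccccc1N1CCN(CCCCCC(=O)NC2CCCc3ccccc32)CC1`: 49.6 nM
- compound 2, `O=C(CCCCCN1CCN(c2ccccc2-c2ccccc2)CC1)NC1CCCc2ccccc21`: 0.13 nM

Both numbers come from an assay on HEK293 cells for displacement of a labelled ligand from 5-hydroxytryptamine receptor 7 (Rattus norvegicus); a higher number here means a weaker inhibitor, a lower number a stronger inhibitor. Going by the values given here, compound 2 stands lowest of the two values, and the only other measured compound is compound 1, which gives a far higher number in this assay. Among the compounds with values here, the single measured step links these two: a 380-fold lower number from compound 1 to compound 2 (2.58 log units; beyond the scatter). That step shows how strongly this assay responds to what sits on this aromatic carbon of the shared core.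

Compound 3, `CNc1ccccc1N1CCN(CCCCCC(=O)NC2CCCc3ccccc32)CC1`, differs from compound 2 in the same place: methylamino in place of phenyl on an aromatic carbon. Within the data shown here, no measured step covers a methylamino group here, so the expectation rests on the one step above. Since replacing propyl by phenyl moved the number down by a large amount, taking the phenyl away again and putting in a methylamino group is expected to move the number back up, most likely by a large step, though its exact size is uncertain. The number for compound 3 is therefore estimated at 15 nM, with a plausible range from 1 nM to 150 nM, which corresponds to an expected step of a 120-fold higher number from compound 2 to compound 3 (2.06 log units; beyond the scatter).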

Compound 3, inhibition constant: 25.4 nM
Estimate against measurement, compound 3: 1.7-fold (0.23 log units) below; measured number inside the range.
By their numbers in this assay, from the lowest: compound 2; then compounds 3 and 1 (each within the scatter of the next).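

Read in this assay this change gives a 200-fold higher number from compound 2 to compound 3 (2.29 log units; beyond the scatter) and so shows that the very low number of compound 2 is lost when a methylamino group replaces the phenyl on this aromatic carbon, ortho to a large group. Comparing the methylamino and propyl groups gives a 2.0-fold lower number from compound 1 to compound 3 (0.29 log units; within the scatter) and this lies within the scatter, so a group holding a nitrogen and a plain carbon chain cannot be told apart at this place, while phenyl stands clearly apart from both among these three compounds. No available evidence explains why phenyl behaves differently from the other two groups.

As far as these compounds go, what remains open is whether any ring at this place would give a number as low as that of compound 2, or whether the result is particular to phenyl; a cyclohexyl or pyridyl ring would separate these possibilities. It is also unsettled whether a methoxy group or a single chlorine atom here would match the methylamino and propyl groups, and whether a shorter chain to the amide would change how much phenyl matters.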